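This account rests on a few compounds, and the source may have more. Where it says the series, first, only, none or still open, it means among the compounds named here.

Measured in a functional assay on MCF7 cells (Homo sapiens) for cytotoxicity, read by MTT assay, with a stated time of 96 h; a higher number here means a weaker inhibitor, a lower number a stronger inhibitor:
Compound 1 `COc1cc(C(=O)c2cn(-c3cccc(C)c3)cc2-c2ccccc2F)cc(OC)c1OC`: 190 nM
Compound 2 `COc1cc(C(=O)c2cn(-c3cccc(C)c3)cc2-c2ccccc2[N+](=O)[O-])cc(OC)c1OC`: 220 nM
Compound 3 `COc1cc(C(=O)c2cn(-c3cccc(C)c3)cc2-c2ccc([N+](=O)[O-])cc2)cc(OC)c1OC`: 780 nM

Compound 3, at 780 nM, has the highest number of the three, which makes it the weakest inhibitor here. Compound 4 `COc1cc(C(=O)c2cn(-c3cccc(C)c3)cc2-c2cccc(N)c2)cc(OC)c1OC` has 3-aminophenyl in place of 4-nitrophenyl on an aromatic carbon. Among the compounds with values here, no measured compound carries 3-aminophenyl, so the evidence is indirect. The two steps that arrive at 4-nitrophenyl are both modest: a 4.1-fold higher number from compound 1 to compound 3 (0.61 log units; beyond the scatter) and a 3.5-fold higher number from compound 2 to compound 3 (0.55 log units; beyond the scatter). The swap of fluoro for nitro barely registers: a 1.2-fold higher number from compound 1 to compound 2 (0.06 log units; within the scatter). Leaving 4-nitrophenyl is therefore expected to give a modest step towards a lower number in this assay, and the estimated step is a 3.1-fold lower number from compound 3 to compound 4 (0.49 log units; beyond the scatter). The estimate for compound 4 is 250 nM, with an expected range from 60 nM to 900 nM.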

Compound 4, half-maximal inhibitory concentration: 130 nM
Estimate against measurement, compound 4: 1.9-fold (0.28 log units) above, and the stated range covers the measured number.
By their numbers in this assay, from the lowest: compounds 4, 1 and 2 (each within the scatter of the next); then compound 3.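

In this assay, this position on the shared core accepts 3-aminophenyl, which, unlike 4-nitrophenyl, carries a hydrogen-bond donor, and the change gives a 6.0-fold lower number from compound 3 to compound 4 (0.78 log units; beyond the scatter). Compound 4 does not separate from the two ortho-free comparisons of the series, however, with a 1.7-fold lower number from compound 2 to compound 4 (0.23 log units; within the scatter) and a 1.5-fold lower number from compound 1 to compound 4 (0.16 log units; within the scatter), so the amine matches 2-nitrophenyl and 2-fluorophenyl here rather than surpassing them. No measurement available here explains these steps. On these data alone, it remains open whether the amine itself matters or leaving 4-nitrophenyl is enough; a phenyl carrying a hydroxyl or an acetamide instead of the amine would separate the two.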